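Adenosine receptor binding: short side chains on a shared core

A few compounds are considered here, and "the series" means these few. Any claim that something is new, unique, unknown or untested is made for them only; others in the source may bear on it.

Compound 1 `CCCn1cnc2ncnc(N)c21` gives > 100000 nM in an assay on CHO cells for displacement of a labelled ligand from adenosine receptor A3 (Homo sapiens); on this read-out lower numbers stand for stronger inhibition and higher numbers for weaker inhibition; this is a limit.
Compound 2 `Nc1ncnc2ncn(CCO)c12` gives > 100000 nM in this assay; this is a limit.

Compound 2 stands only at a limit in this assay, with no number to place it. The step that the two limits leave unreadable from compound 1 to compound 2 cannot be read, since both ends sit at the limit (the limit of > 100000 nM in this assay, at which 2 of the 2 values shown sit). Compound 3 `CC(O)Cn1cnc2ncnc(N)c21` differs from compound 2 by methyl in place of hydrogen on a saturated chain carbon bound to an oxygen on a saturated carbon and a saturated chain carbon. Within the data shown here, no measured step of readable size bears on this change. As both values sit at the limit (the limit of > 100000 nM in this assay, at which 2 of the 2 values shown sit), compound 3 is expected to stay at it. The step that the limit leaves unreadable from compound 2 to compound 3 is expected to be none beyond the scatter. Compound 3 is estimated at 150000 nM, range 30000 nM to 1000000 nM.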

Compound 3, inhibition constant: > 100000 nM
Compound 3: no number, only a limit (the forecaster's own chance of this, stated with the estimate: 85%); the middle value is on the limit's open side.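

No new step can be read among compound 1, compound 2 and compound 3, since all three stand only at a limit: the limit of > 100000 nM in this assay, at which 3 of the 3 values shown sit. The compounds shown leave open whether any short side chain on the shared core gives a readable value in this assay at all.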